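The source may hold more compounds than are shown below. What is called first, only, known or untested is meant among the compounds shown, and "the series" means these compounds.

Compound 1 `O=C(COCc1ccccc1)N1CCN(c2ccccc2)CC1`: "not determined" (no result reported)
Compound 2 `O=C(COCc1ccccc1)N1CCN(c2ccc(Cl)cc2)CC1`: 290 mL.min-1.g-1
Compound 3 `O=C(COCc1ccccc1)N1CCN(c2ccc(F)cc2)CC1`: 110 mL.min-1.g-1

These three compounds were examined in an in vitro ADME assay on microsomes from liver (Homo sapiens) for metabolic stability; a lower number here means slower removal, a higher number faster removal of the compound. Only compound 2 and compound 3 have numbers, and compound 3 has the lower of the two, at 110 mL.min-1.g-1. The nearest neighbour of compound 3 is compound 2 at 290 mL.min-1.g-1, and compound 1 offers no comparison.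

The next compound is compound 4 `O=C(COCc1ccccc1)N1CCN(c2ccc(F)cc2Cl)CC1`, which has chloro in place of hydrogen on an aromatic carbon, ortho to a large group and meta to a fluoro group: chloro in place of hydrogen on an aromatic carbon. The 4-fluorophenyl of compound 3 thus becomes 2-chloro-4-fluorophenyl.

For the measured compounds named here, one measured step bears on this, and only indirectly: a 2.6-fold lower number from compound 2 to compound 3 (0.42 log units; beyond the scatter). It is a modest step beyond the scatter, with fluoro in place of chloro, so the compound carrying chloro has the higher number. That step is a swap, whereas compound 4 gains a chloro and keeps its fluoro, so the evidence is thin. A modest rise in this assay is expected, smaller than the measured step and possibly within the scatter. The expected change is a 1.6-fold higher number from compound 3 to compound 4 (0.21 log units; within the scatter). For compound 4 the estimated value is 180 mL.min-1.g-1, with an expected range from 80 mL.min-1.g-1 to 400 mL.min-1.g-1.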

Compound 4, intrinsic clearance in microsomes: 530 mL.min-1.g-1
For compound 4 the middle estimate is 2.9-fold (0.47 log units) below the measured one; the measured number lies above the stated range.
By their numbers in this assay, from the lowest: compound 3; then compounds 2 and 4 (each within the scatter of the next).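

In this assay, for the compounds shown here, chloro in place of hydrogen on an aromatic carbon, ortho to a large group and meta to a fluoro group, gives a 4.8-fold higher number from compound 3 to compound 4 (0.68 log units; beyond the scatter), so this position responds clearly to substitution, and the change is the first to add a group to the ring rather than swap one for another. The other new comparison, 2-chloro-4-fluorophenyl in place of 4-chlorophenyl, gives a 1.8-fold higher number from compound 2 to compound 4 (0.26 log units; within the scatter), which means that compound 4 keeps the fluoro group of compound 3 and yet cannot be separated from compound 2, so the fluoro group alone does not secure the lower number of compound 3. Nothing in the data shown accounts for the size of this rise.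

As far as these compounds go, whether the rise belongs to chloro itself, or would also follow a methyl or a methoxy group at the same place, stays open, as does the outcome of chloro at this place on a ring without the fluoro group. Compound 1 gives "not determined" (no result reported), so the plain phenyl offers no reference point for judging either halogen.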